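The compounds below may be only part of what the source reports. "The series", "measured", "known", "first", "only" and "open" are said of these compounds alone.

The measured compounds:
compound 1, `C/C(=C\c1ccc(-c2ccc(C)cc2)o1)C(N)=O`, gives > 50000 nM in a functional assay on BGC-823 cells (Homo sapiens) for cytotoxicity, read by CCK-8 assay, with a stated time of 24 h; on this read-out lower numbers stand for stronger inhibition and higher numbers for weaker inhibition.
compound 2, `C/C(=C\c1ccc(-c2ccc(F)cc2)o1)C(N)=O`, gives 940 nM in this assay.
compound 3, `C/C(=C\c1nc(-c2ccc(C)cc2)cs1)C(N)=O`, gives > 50000 nM in this assay.

For compound 1 the value is a limit of the assay and not a number. Compound 2 shares the core of compound 1 and gives a number, so the step of an at least 53-fold lower number from compound 1 to compound 2 (1.72 log units; beyond the scatter) follows from the change (fluoro in place of methyl on an aromatic carbon). For compound 3 the value is again a limit; this is the limit of > 50000 nM in this assay, at which 2 of the 3 values shown sit. How the core of compound 3 differs from the core of compound 1 is not broken down here.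

Compound 4, `C/C(=C\c1nc(-c2ccc(F)cc2)cs1)C(N)=O`, is not yet measured. It differs from compound 3 by fluoro in place of methyl on an aromatic carbon, the same change that was made from compound 1 to compound 2, at a place described in the same words. Because compound 3 sits at the limit of > 50000 nM in this assay, at which 2 of the 3 values shown sit, the earlier step can only be carried over with caution. For compound 4 a step of an at least 8.3-fold lower number from compound 3 to compound 4 (0.92 log units; beyond the scatter) is expected. This expectation rests on compound 2, which reached 940 nM on its own core. Compound 3, by contrast, gives only a limit. The estimate for compound 4 is 6000 nM, between 900 nM and 50000 nM.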

Compound 4, half-maximal inhibitory concentration: > 50000 nM
Compound 4 was reported as a limit; the forecaster's own chance of this, stated with the estimate: 35%; at least 8.3-fold (0.92 log units) between middle value and limit.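

Compound 4 gives > 50000 nM in this assay, which is a limit of the assay and not a number. Compound 3 also gives a limit, so no step between compound 3 and compound 4 can be read, and both stand at the same place: the limit of > 50000 nM in this assay, at which 3 of the 4 values shown sit.

The compounds shown leave open whether fluoro in place of methyl changes the value at all on the core of compound 3, as it did on the core of compound 1.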